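Phenyl to pyridin-3-yl: working notes on the series

The source may report more compounds than this note shows. Statements on the series, on what has been measured and on what is new or still open speak of the compounds shown alone.

Values measured in a functional assay on MCF-10A cells (Homo sapiens) for antiproliferative activity, with a stated time of 48 h (on this read-out higher numbers stand for an effect only at larger amounts of compound and lower numbers for an effect already at smaller amounts), are as follows
Compound 1 `COc1ccc2nc(C)cc(NCc3ccccc3)c2c1` gives 28600 nM
Compound 2 `COc1ccc2nc(C)cc(NCc3ccncc3)c2c1` gives 41600 nM

Going by the values given here, compound 1 is one of only two measured compounds, and compound 2 sits within the scatter of it. Compound 3 `COc1ccc2nc(C)cc(NCc3cccnc3)c2c1` carries pyridin-3-yl in place of phenyl on a saturated chain carbon bound to a nitrogen on an aromatic ring and is not yet measured. Among the compounds with values here, the one step bearing on this change is pyridin-4-yl in place of phenyl at that place (a 1.5-fold higher number from compound 1 to compound 2 (0.16 log units; within the scatter)), which lies within the scatter. No step beyond the scatter is therefore expected in this assay for this change. The expected step (a 1.2-fold higher number from compound 1 to compound 3 (0.09 log units; within the scatter)) is an estimate only. Compound 3 is expected at 35000 nM (estimated range 18000 nM to 65000 nM) on this read-out.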

Compound 3, half-maximal effective concentration: 49300 nM
The estimate for compound 3 lay 1.4-fold (0.15 log units) below the measured number; low and high end bracket the measured number.
By their numbers in this assay, from the lowest: compounds 1, 2 and 3 (each within the scatter of the next).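

In the assay (this assay), pyridin-3-yl in place of phenyl on a saturated chain carbon bound to a nitrogen on an aromatic ring gives a step (a 1.7-fold higher number from compound 1 to compound 3 (0.24 log units; within the scatter)), and pyridin-3-yl in place of pyridin-4-yl gives another (a 1.2-fold higher number from compound 2 to compound 3 (0.07 log units; within the scatter)). Compounds 1, 2 and 3 therefore cannot be told apart here, whether the ring is phenyl, pyridin-4-yl or pyridin-3-yl. No supporting data bear on this result.

The compounds shown leave open whether an amine on the ring, a carboxylic acid on the ring or a longer chain in place of benzyl would give a step beyond the scatter.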